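One Fluorinated Group Exchanged on Compound 2

This account rests on a few compounds, and the source may have more. Where it says the series, first, only, none or still open, it means among the compounds named here.

Measured so far in a functional assay on DU-145 cells (Homo sapiens) for antiproliferative activity, read by propidium iodide staining, with a stated time of 96 h; on this read-out higher numbers stand for weaker inhibition and lower numbers for stronger inhibition:
- compound 1 `CC(O)(CSc1cccc(S(F)(F)(F)(F)F)c1)C(=O)Nc1ccc(C#N)cc1C(F)(F)F`: 37400 nM
- compound 2 `CC(O)(CSc1ccc(S(F)(F)(F)(F)F)cc1)C(=O)Nc1ccc(S(F)(F)(F)(F)F)cc1`: 22300 nM

Compound 2, at 22300 nM, lies within the usual scatter of compound 1, at 37400 nM, so the two cannot be ranked. Compound 3 `CC(O)(CSc1ccc(C(F)(F)F)cc1)C(=O)Nc1ccc(S(F)(F)(F)(F)F)cc1` differs from compound 2 at a single place, on an aromatic carbon, para to a large group: a group of 4 heavy atoms (1 carbon, 3 fluorine; no ring) in place of a group of 6 heavy atoms (5 fluorine, 1 sulfur; no ring), on an aromatic carbon. A trifluoromethyl enters there. For the measured compounds named here, no measured pair differing in one place gives a size for such a change, so nothing beyond the scatter is expected in this assay, and no direction is favoured. The estimated step of a 1.1-fold higher number from compound 2 to compound 3 (0.05 log units; within the scatter) is expected to stay small. Compound 3 is expected to give about 25000 nM, with an estimated range of 10000 nM to 60000 nM.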

Compound 3, half-maximal inhibitory concentration: 28800 nM
The estimate for compound 3 lay 1.2-fold (0.06 log units) below the measured number, within the range that was stated.
By their numbers in this assay, from the lowest: compounds 2, 3 and 1 (each within the scatter of the next).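

In this assay the exchange of the group of 5 fluorine and 1 sulfur for a trifluoromethyl, on an aromatic carbon para to a large group, gives a 1.3-fold higher number from compound 2 to compound 3 (0.11 log units; within the scatter) and so supplies the only size so far for a change in one place among these compounds. At this position, with the rest of compound 2 unchanged, the two groups cannot be told apart on this read-out, although one has 6 heavy atoms and the other 4. No supporting measurement bears on this result.

The compounds shown leave open whether a group of a different kind on this same carbon, such as an amine or a carboxylic acid, would give a step beyond the scatter. They also leave open whether the same exchange on the other aromatic ring would stay as small.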